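The source may report more compounds than this note shows. Statements on the series, on what has been measured and on what is new or still open speak of the compounds shown alone.

Of the compounds shown here, three have been tested in an assay on COS-7 cells for inhibition of patatin-like phospholipase domain-containing protein 2 (Mus musculus), tested at 200 uM (a higher number here means more inhibition at the concentration tested (going by the name of the read-out), a lower number less inhibition), and compound 1 `CCOC(=O)c1cccc(-c2ccc(OC)cc2)c1` stands second highest among those three numbers with 77%. Its nearest neighbour is compound 2 `CCOC(=O)c1cccc(-c2ccc3[nH]ccc3c2)c1`, which gives 80%, a value within the usual scatter of compound 1, so the two cannot be told apart. The furthest is compound 3 `CCOC(=O)c1cccc(-c2ccc(CN3CCN(S(C)(=O)=O)CC3)o2)c1`, which gives 66%, a number beyond the scatter on the lower side.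

Compound 4 `CCOC(=O)c1cccc(-c2ccc(C(C)=O)cc2)c1` has not been measured yet. It differs from compound 1 in one place: acetyl in place of methoxy on an aromatic carbon. Both groups carry one hydrogen-bond acceptor and no donor, and the acetyl is larger by one heavy atom.

Within the data shown here, no pair of measured compounds differs in only one place, so there is no measured step to lean on. What the numbers do show is that all three measured compounds fall in a fairly narrow band, and compound 1 and compound 2, which differ widely in their outer group, sit within the scatter of each other. The step of a number 5 percentage points lower from compound 1 to compound 4 (within the scatter) is therefore expected to be small, either direction, and not beyond the scatter. Compound 4 is expected to give about 72%, with a range from 55% to 88%.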

Compound 4, a percentage reported as inhibition, at one concentration (the size of the read-out at that concentration, not a potency): 36%
Estimate against measurement, compound 4: 36 percentage points above; the whole stated range lies above it.
By their numbers in this assay, from the lowest: compound 4; then compound 3; then compounds 1 and 2 (each within the scatter of the next).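

In this assay, among these compounds, putting acetyl in place of methoxy on the aromatic carbon para to a large group gives a number 41 percentage points lower from compound 1 to compound 4 (beyond the scatter), so this position is sensitive to what sits on it, which the earlier compounds, with no single-place step among them, could not show. The two groups have the same counts of hydrogen-bond donors and acceptors and differ by only one heavy atom, so for this pair those counts do not predict the result, and a small change in the outer group can matter far more than the narrow band of the first three numbers suggested. No measurement at hand gives a reason for this step.

The compounds shown leave open whether the carbonyl of the acetyl or its extra heavy atom goes with the lower number, a question that a hydroxyl, an ethyl or an amine at the same place could help to separate. They also leave open whether the same exchange would have a similar effect on another core, as this is a single step read at one concentration.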